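The compounds below may be only part of what the source reports. "The series", "measured", "known", "first", "only" and "open" are said of these compounds alone.

Two compounds of this series have been run in a functional assay on HCC1806 cells (Homo sapiens) for inhibition, read by sulforhodamine B assay, tested at 10 uM (on this read-out higher numbers stand for more inhibition at the one concentration tested (going by the name of the read-out) and lower numbers for less inhibition), so far. Compound 1 `CN1CCN(c2ccc(C3=NN(C(=O)CCCl)C(c4ccc(N(C)C)cc4)C3)cc2)CC1` carries a 2-chloroethyl on the carbonyl carbon of the acyl group on the ring nitrogen; in this assay compound 1 gives 1.7%. Compound 2 `Cc1ccc(C(=O)N2N=C(c3ccc(N4CCN(C)CC4)cc3)CC2c2ccc(N(C)C)cc2)cc1` carries a 4-methylphenyl in that place and in this assay compound 2 gives -2.5%. Among the measured compounds shown here, the only step measured so far, a number 4.2 percentage points lower from compound 1 to compound 2 (within the scatter), is within the scatter, so compound 2 sits with compound 1 at the low end of the read-out, the two numbers indistinguishable and both close to no inhibition.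

The next compound, compound 3 `CN1CCN(c2ccc(C3=NN(S(C)(=O)=O)C(c4ccc(N(C)C)cc4)C3)cc2)CC1`, changes the same position once more: methylsulfonyl in place of (4-methylphenyl)carbonyl on an amine nitrogen in a ring. For the measured compounds named here, the single step that bears on this change is the exchange at the same nitrogen, a number 4.2 percentage points lower from compound 1 to compound 2 (within the scatter), which stayed flat. Nothing measured points to a move in either direction, so the expectation for compound 3 is a step of a number 3.5 percentage points higher from compound 2 to compound 3 (within the scatter), that is none beyond the scatter. Compound 3 is therefore estimated at 1% in this assay, with a range from -10% to 13%.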

Compound 3, a percentage reported as inhibition, at one concentration (the size of the read-out at that concentration, not a potency): -18.5%
Compound 3: the middle estimate sits 19.5 percentage points above what was measured; the whole stated range lies above it.
By their numbers in this assay, from the lowest: compound 3; then compounds 2 and 1 (each within the scatter of the next).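

The position on an amine nitrogen in a ring is not as flat in this assay as the first pair suggested: the methylsulfonyl group gives a number 16 percentage points lower from compound 2 to compound 3 (beyond the scatter), and a number 20.2 percentage points lower from compound 1 to compound 3 (beyond the scatter), both in the direction of less inhibition. The two groups attached through a carbonyl, one with a six-membered aromatic ring and one with a 2-chloroethyl chain, stay within the scatter of each other, so among these three compounds the change that registers is the exchange of a carbonyl-linked group for methylsulfonyl, not the exchange of one carbonyl-linked group for another. No measurement bears on why the methylsulfonyl group moves the number in this way.

Compared with compound 2, compound 3 swaps the carbonyl link for a sulfonyl link and also loses the aromatic ring, so a phenylsulfonyl or an acetyl group on the same nitrogen would be needed to separate the two changes. On these data alone, it also remains open whether any group at this nitrogen, such as a chain ending in an amine or a carboxylic acid, can raise the number clearly above that of compound 1.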